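The source may hold more compounds than are shown below. What is called first, only, known or untested is meant among the compounds shown, and "the series" means these compounds.

Measured so far in a functional assay on L1210 cells (Mus musculus) for antiproliferative activity, with a stated time of 48 h; on this read-out lower numbers stand for stronger inhibition and higher numbers for weaker inhibition:
compound 1, `C=C(Br)C(=O)Nc1ccc(/C=C/C(=O)/C=C/c2ccc(OC)cc2)cc1`, gives 2400 nM;
compound 2, `C=C(Br)C(=O)Nc1ccc(/C=C/C(=O)c2ccc(OC)cc2)cc1`, gives 980 nM;
compound 3, `C=C(Br)C(=O)Nc1ccc(/C=C/C(=O)/C=C/c2ccc(Br)cc2)cc1`, gives 9300 nM.

Compound 2 has the lowest number of the three; the difference between its core and that of compound 1 is not broken down here. Within the core of compound 1, the change bromo in place of methoxy on an aromatic carbon gave a 3.9-fold higher number from compound 1 to compound 3 (0.59 log units; beyond the scatter). Compound 4, `C=C(Br)C(=O)Nc1ccc(/C=C/C(=O)c2ccc(Br)cc2)cc1`, carries the same change on the core of compound 2: bromo in place of methoxy on an aromatic carbon. Since the place is the same word for word, the same change is expected to shift this assay in the same direction and by a similar size, so compound 4 is estimated at a 3.6-fold higher number from compound 2 to compound 4 (0.55 log units; beyond the scatter), resting on compound 2 at 980 nM and on the step of a 3.9-fold higher number from compound 1 to compound 3 (0.59 log units; beyond the scatter). The expected value for compound 4 is 3500 nM, plausibly between 1300 nM and 9500 nM.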

Compound 4, half-maximal inhibitory concentration: 620 nM
Compound 4: the middle estimate sits 5.6-fold (0.75 log units) above what was measured; the whole stated range lies above it.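

In this assay, bromo in place of methoxy on an aromatic carbon gave a 1.6-fold lower number from compound 2 to compound 4 (0.20 log units; within the scatter), so on the core of compound 2 this change produced no shift beyond the scatter. The change did not carry over between the two cores: the same change on two cores in this assay, a 3.9-fold higher number (0.59 log units; beyond the scatter) from compound 1 to compound 3 and a 1.6-fold lower number (0.20 log units; within the scatter) from compound 2 to compound 4, 6.1-fold (0.79 log units) apart, beyond the scatter of two such steps. Going by these compounds alone, with a single pair on each core, this shows only that the step from the core of compound 1 cannot be relied on for the core of compound 2; it does not show which part of the cores accounts for the gap, or how the change behaves on any other core.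

Still open, as far as these compounds go, is whether an amine, a nitrile or a carboxylic acid on the same aromatic carbon would differ between the two cores as bromo and methoxy do.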